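A few compounds are considered here, and "the series" means these few. Any claim that something is new, unique, unknown or untested is made for them only; others in the source may bear on it.

Working notes on the series. Going by the values given here, in a functional assay on TOV112D cells (Homo sapiens) for antiproliferative activity, read by CellTiter-Glo, with a stated time of 96 h (a lower number here means a stronger inhibitor, a higher number a weaker inhibitor), compound 3 (`COc1ccc(-c2nsc3c2NC(=O)CC3c2ccsc2)cc1`) gives 136 nM and holds the lowest of the three numbers so far. Compound 1 (`COc1ccc(-c2nsc3c2NC(=O)CC3c2cccc(OC)c2)cc1`) stands at 808 nM and compound 2 (`COc1ccc(-c2nsc3c2NC(=O)CC3c2cccc(Cl)c2)cc1`) at 1270 nM in the same test. Both sit beyond the scatter from compound 3, as the steps show: a 5.9-fold lower number from compound 1 to compound 3 (0.77 log units; beyond the scatter) and a 9.3-fold lower number from compound 2 to compound 3 (0.97 log units; beyond the scatter) with thiophen-3-yl on a saturated ring carbon. Those two steps concern another site and say nothing direct about the next change.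

Next is compound 4 (`O=C1CC(c2ccsc2)c2snc(-c3ccc(Cl)cc3)c2N1`), which differs from compound 3 as follows: chloro in place of methoxy on an aromatic carbon (chloro in place of methoxy on an aromatic carbon, para to a large group). Among the compounds with values here, the one measured step with the same exchange is a 1.6-fold higher number from compound 1 to compound 2 (0.20 log units; within the scatter) at a different aromatic carbon, so it is a loose guide and no measured step covers this exact site. On that single precedent, no step beyond the scatter is expected in this assay, with a slight allowance towards a higher number. The expected step is a 1.5-fold higher number from compound 3 to compound 4 (0.17 log units; within the scatter) as an estimate only. For compound 4 the estimated value is 200 nM with an expected range from 70 nM to 600 nM for now.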

Compound 4, half-maximal inhibitory concentration: 1150 nM
Estimate against measurement, compound 4: 5.8-fold (0.76 log units) below; the whole stated range lies below it.
By their numbers in this assay, from the lowest: compound 3; then compounds 1, 4 and 2 (each within the scatter of the next).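

In this assay, the exchange of methoxy for chloro on this aromatic carbon, para to a large group, is not neutral on the core of compound 3: the step is an 8.5-fold higher number from compound 3 to compound 4 (0.93 log units; beyond the scatter). The near-flat result for the same exchange at the other aromatic carbon therefore does not carry over to this position, and the exchange has no single size across the compounds shown: the same change on two cores in this assay, a 1.6-fold higher number (0.20 log units; within the scatter) from compound 1 to compound 2 and an 8.5-fold higher number (0.93 log units; beyond the scatter) from compound 3 to compound 4, 5.4-fold (0.73 log units) apart, beyond the scatter of two such steps Methoxy brings one hydrogen-bond acceptor and chloro none, but this single pair cannot tie the step to that count or to any other difference between the two groups.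

Only methoxy and chloro are shown at this position, so it remains open whether the higher number reflects the loss of methoxy or something particular to chloro, and an ethoxy, a hydroxyl or an amine on the same carbon would help separate those readings. Also open, from the compounds shown here alone, is how much of the size of the step depends on thiophen-3-yl on the saturated ring carbon, since this position has been compared with that group alone.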